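Halogen Swap on an Aromatic Carbon: From Compound 2 to 3

This account rests on a few compounds, and the source may have more. Where it says the series, first, only, none or still open, it means among the compounds named here.

Compound 1, `c1ccc(-c2cn3ccnc3c(-c3ccc4ncn(C5CCCCC5)c4c3)n2)cc1`: 55.2%
Compound 2, `Fc1ccc(-c2cn3ccnc3c(-c3ccc4ncn(C5CCCCC5)c4c3)n2)cc1`: 37.8%

In a functional assay on UO-31 cells (Homo sapiens) for inhibition, read by sulforhodamine B assay, with a stated time of 48 h, tested at 10 uM (on this read-out higher numbers stand for more inhibition at the one concentration tested (going by the name of the read-out) and lower numbers for less inhibition), compound 1 gives 55.2%, while compound 2 gives 37.8%. Going by the values given here, compound 2 therefore stands lowest of the two measured numbers, and the single measured step, a number 17.4 percentage points lower from compound 1 to compound 2 (beyond the scatter), lies beyond the scatter.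

Compound 3, `Clc1ccc(-c2cn3ccnc3c(-c3ccc4ncn(C5CCCCC5)c4c3)n2)cc1`, has not yet been measured in this assay. It differs from compound 2 in one place: chloro in place of fluoro on an aromatic carbon.

Among the compounds with values here, only one measured step touches this position, the one where hydrogen became fluoro, and it ran downward by a modest amount. Within the data shown here, no measured pair compares fluoro with chloro, so the direction of the new step cannot be read from the numbers at hand. Among the measured compounds shown here, the one step that exists suggests that changes at this aromatic carbon move the read-out by a modest margin rather than a large one.

For compound 3 a step of a number 4.2 percentage points higher from compound 2 to compound 3 (within the scatter) is expected, which may sit within the scatter. Compound 3 is estimated at 42% in this assay, in a range from 25% to 60%.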

Compound 3, a percentage reported as inhibition, at one concentration (the size of the read-out at that concentration, not a potency): 36.1%
Compound 3: the middle estimate sits 5.9 percentage points above what was measured; measured number inside the range.
By their numbers in this assay, from the lowest: compounds 3 and 2 (each within the scatter of the next); then compound 1.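

In this assay, going by these compounds alone, the swap from 4-fluorophenyl to 4-chlorophenyl gives the first direct comparison of two halogens on this aromatic carbon, para to a large group, and a number 1.7 percentage points lower from compound 2 to compound 3 (within the scatter) means that the assay does not tell these two halogens apart. The step from hydrogen now has a second case: a number 19.1 percentage points lower from compound 1 to compound 3 (beyond the scatter) sits alongside a number 17.4 percentage points lower from compound 1 to compound 2 (beyond the scatter), and both lie beyond the scatter, so each halogen shown here reads lower than the hydrogen of compound 1. Nothing available accounts for the lower reading with either halogen or for the close agreement between them.

From the compounds shown here alone, it remains open whether a different kind of group on this carbon, such as an amine, a methoxy group or a carboxylic acid, would read near compound 1, near the two halogen compounds or elsewhere. Going by these compounds, it also remains open whether hydrogen and the two halogens would keep this same relation at another carbon of the ring or on other cells.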